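Cytotoxicity of a Tetrahydroisoquinoline Series: Toward Compound 4

This account rests on a few compounds, and the source may have more. Where it says the series, first, only, none or still open, it means among the compounds named here.

Measured compounds:
Compound 1 `CN1Cc2ccc(OCc3ccc([N+](=O)[O-])cc3)cc2[C@@H](O)C1`: > 50000 nM
Compound 2 `CN1Cc2ccc(OCCCN3CCNCC3)cc2[C@@H](O)C1`: > 100000 nM
Compound 3 `CN1Cc2ccc(OCc3cccc(Br)c3)cc2[C@@H](O)C1`: 60300 nM

The three compounds share one core and differ only in the group attached through the ether oxygen. In an ADME assay on Vero cells (Chlorocebus sabaeus) for cytotoxicity, read by sulforhodamine B assay, with a stated time of 72 h (on this read-out higher numbers stand for weaker inhibition and lower numbers for stronger inhibition), compound 1 gives > 50000 nM, which is a limit of the assay and not a number. Compound 2 likewise gives > 100000 nM, again only a limit. Going by the values given here, compound 3, which carries a bromophenyl group, is the single compound with a measured number, at 60300 nM. Compound 1 therefore stands among the two compounds at a limit, and the three values together show no spread that can be read as a pattern.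

Compound 4 `CN1Cc2ccc(OCc3ccc(-c4cccc(Cl)c4)cc3)cc2[C@@H](O)C1` has not yet been tested. It differs from compound 1 in one place: 3-chlorophenyl in place of nitro on an aromatic carbon. Among the compounds with values here, no measured pair describes such a change, so the size of the step has to be guessed. A small shift toward stronger inhibition, within or only just beyond the scatter, is expected, as an at least 1.4-fold lower number from compound 1 to compound 4 (0.15 log units; that floor lies within the scatter). The estimated value for compound 4 is 35000 nM, with a range from 12000 nM to 100000 nM.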

Compound 4, half-maximal inhibitory concentration: 25500 nM
For compound 4 the middle estimate is 1.4-fold (0.14 log units) above the measured one, and the stated range covers the measured number.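

In this assay, going by these compounds alone, putting 3-chlorophenyl in place of nitro, on an aromatic carbon para to a large group, gives an at least 1.9-fold lower number from compound 1 to compound 4 (0.29 log units; that floor lies within the scatter) and is the first step that can be read at all. This step is only a floor because compound 1 sits at a limit and not at a number: the limit of > 50000 nM in this assay, at which 1 of the 4 values shown sits. The result shows that this place accepts the larger group with its aromatic ring, but with the floor inside the scatter, it does not establish a real gain in inhibition.

The compounds shown leave open whether the chlorine or the added ring accounts for the step, which an unsubstituted phenyl at this place would separate. They also leave open how an amine or a carboxylic acid on that ring would read in this assay.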